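The source may report more compounds than this note shows. Statements on the series, on what has been measured and on what is new or still open speak of the compounds shown alone.

Of the compounds shown here, two sharing one core have been measured so far in a functional assay on HeLa cells (Homo sapiens) for antiproliferative activity, read by MTT assay, with a stated time of 72 h; a higher number here means a weaker inhibitor, a lower number a stronger inhibitor. Compound 1 `COc1ncc(-c2ccc3c(c2)N(C2CCCCC2)C(=O)CO3)cc1NS(=O)(=O)c1ccc(F)cc1` gives 6100 nM, and compound 2 `COc1ccc(N2C(=O)COc3ccc(-c4cnc(OC)c(NS(=O)(=O)c5ccc(F)cc5)c4)cc32)cc1` gives 1220 nM, the lower of the two numbers and therefore the stronger result. Going by the values given here, the only measured step is a 5.0-fold lower number from compound 1 to compound 2 (0.70 log units; beyond the scatter), which comes with 4-methoxyphenyl in place of cyclohexyl on an amide-type nitrogen in a ring.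

Compound 3 `COc1ncc(-c2ccc3c(c2)N(C(C)C)C(=O)CO3)cc1NS(=O)(=O)c1ccc(F)cc1` changes that same nitrogen, with isopropyl in place of 4-methoxyphenyl on an amide-type nitrogen in a ring. Isopropyl has no ring, so it differs from cyclohexyl as well, and no measured compound carries it. The closest guide is compound 1, which also lacks the 4-methoxyphenyl group and sits at 6100 nM. A higher number is therefore expected in this assay, in a step similar to or somewhat smaller than the measured one, though a single pair is thin evidence. The estimated change is a 3.3-fold higher number from compound 2 to compound 3 (0.52 log units; beyond the scatter). The expected value for compound 3 is 4000 nM, with an estimated range from 1300 nM to 12000 nM.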

Compound 3, half-maximal inhibitory concentration: 2790 nM
Beside the measured number, compound 3's estimate is 1.4-fold (0.16 log units) above it, and the stated range covers the measured number.
By their numbers in this assay, from the lowest: compound 2; then compound 3; then compound 1.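

In this assay the open-chain isopropyl group lands in the middle of the series, with a 2.3-fold higher number from compound 2 to compound 3 (0.36 log units; beyond the scatter) and also a 2.2-fold lower number from compound 1 to compound 3 (0.34 log units; beyond the scatter). The first two compounds alone could suggest that any ring on this amide-type nitrogen was no advantage over a group lacking the 4-methoxyphenyl, or that the contrast was simply aromatic ring against non-aromatic ring, but compound 3 adds a third kind of group and shows that the position does not divide into just two levels: the ring-free isopropyl gives a lower number than the ring-bearing cyclohexyl, so having a ring here does not by itself lower the number, and compound 2 shows that one particular ring, the 4-methoxyphenyl, still gives the lowest number of the three. Nothing measured here explains this order.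

The compounds shown leave open whether the lower number of compound 2 belongs to the six-membered aromatic ring or to its methoxy oxygen, which a plain phenyl group at this nitrogen would help to separate. They also leave open how a smaller methyl group, a longer chain such as n-butyl, or a chain ending in an amine would rank against isopropyl.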